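Working notes: methoxy in place of hydrogen on compound 1

The compounds below may be only part of what the source reports. "The series", "measured", "known", "first", "only" and "open" are said of these compounds alone.

In a functional assay on PC-3 cells (Homo sapiens) for inhibition, read by sulforhodamine B assay, with a stated time of 48 h (a lower number here means a stronger inhibitor of growth, a higher number a weaker inhibitor of growth), compound 1 `CC1(/C=C/c2ccccc2)C=CC(=O)O1` gives 86900 nM and shares the high end of the three numbers with compound 3 `CC1(/C=C/c2cccc(O)c2)C=CC(=O)O1` at 98800 nM while compound 2 `CC1(/C=C/c2ccc(C(F)(F)F)cc2)C=CC(=O)O1` lies clearly lower at 13100 nM in the same read-out.

Compound 4 `COc1ccccc1/C=C/C1(C)C=CC(=O)O1` carries one change on the core of compound 1, methoxy in place of hydrogen on an aromatic carbon, counted as methoxy in place of hydrogen on an aromatic carbon here.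

Going by the values given here, two measured steps bear on this change, each replacing hydrogen on an aromatic carbon. Trifluoromethyl gave a 6.6-fold lower number from compound 1 to compound 2 (0.82 log units; beyond the scatter) as a modest step. Hydroxy gave a 1.1-fold higher number from compound 1 to compound 3 (0.06 log units; within the scatter) and, with methoxy also attaching through oxygen, this is the step the expectation leans on. The trifluoromethyl step is kept only as a reason to allow some room toward a lower number.

No step beyond the scatter is expected in this assay and the estimated step is a 1.2-fold lower number from compound 1 to compound 4 (0.09 log units; within the scatter) in the direction of a slightly lower number.

Compound 4 is estimated at 70000 nM with an expected range from 25000 nM to 150000 nM.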

Compound 4, concentration for total growth inhibition: 34200 nM
Compound 4: middle estimate off by 2.0-fold (0.31 log units), on the high side; the measured number falls inside the stated range.
By their numbers in this assay, from the lowest: compound 2; then compound 4; then compounds 1 and 3 (each within the scatter of the next).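

In this assay, methoxy on an aromatic carbon, ortho to a group of 9 heavy atoms, gives a 2.5-fold lower number from compound 1 to compound 4 (0.40 log units; beyond the scatter), so a group attached through oxygen can move the number beyond the scatter on this ring, which the hydroxy step, a 1.1-fold higher number from compound 1 to compound 3 (0.06 log units; within the scatter), did not show. Trifluoromethyl is therefore no longer the only substituent in the series with a step to a lower number: a 6.6-fold lower number from compound 1 to compound 2 (0.82 log units; beyond the scatter), is now joined by a second step in the same direction, from a group at a different place on the ring. No measurement is available to explain the methoxy step.

Still open, as far as these compounds go, is whether this step follows the group or its place, as hydroxy, methoxy and trifluoromethyl each occupy a different ring position and no single position carries two of them. Also open, from the compounds shown here alone, is how an amine or a longer ether chain such as ethoxy would read ortho to the group of 9 heavy atoms, and how methoxy would read at the places held by hydroxy in compound 3 and trifluoromethyl in compound 2.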